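This account rests on a few compounds, and the source may have more. Where it says the series, first, only, none or still open, it means among the compounds named here.

In an ADME assay on HeLa cells (Homo sapiens) for antiproliferative activity, read by MTT assay, with a stated time of 72 h (on this read-out lower numbers stand for stronger inhibition of growth and higher numbers for weaker inhibition of growth), compound 2 `Clc1ccc(/C=C/c2c[nH]c3ccccc23)cc1` gives 64000 nM, the higher of the two numbers measured here. Its nearest companion is compound 1 `Brc1ccc(/N=N/c2c[nH]c3ccccc23)cc1`, which in this assay gives 49000 nM; the gap between the two lies within the scatter, so the two compounds cannot be told apart on this read-out.

Compound 3 `Clc1ccc(/C=C/c2[nH]c3ccccc3c2/C=C/c2ccc(Cl)cc2)cc1` has not yet been measured. It differs from compound 2 in one place: 2-(4-chlorophenyl)ethenyl in place of hydrogen on an aromatic carbon. The group that enters sits on an aromatic carbon of a five-membered aromatic ring with one nitrogen, part of a fused system of two rings, next to the ring nitrogen and next to the ring atom that already bears a 2-(4-chlorophenyl)ethenyl group. Compound 3 therefore carries two of these groups where compound 2 carries one.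

Within the data shown here, no pair of measured compounds shows what such an addition does in this assay, so there is no step to lean on. For compound 3 the expected change from compound 2 is small, with no clear direction, and is written as a 1.6-fold lower number from compound 2 to compound 3 (0.20 log units; within the scatter). The estimate for compound 3 in this assay is 40000 nM, expected to fall between 8000 nM and 150000 nM.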

Compound 3, concentration for 50% growth inhibition: 69000 nM
Beside the measured number, compound 3's estimate is 1.7-fold (0.24 log units) below it; measured number inside the range.
By their numbers in this assay, from the lowest: compounds 1, 2 and 3 (each within the scatter of the next).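

In this assay, among these compounds, the step from one group to two reads as a 1.1-fold higher number from compound 2 to compound 3 (0.03 log units; within the scatter), and it is the first step in this set that tests a change at this position. Placing a 2-(4-chlorophenyl)ethenyl group on this aromatic carbon, next to the ring nitrogen and next to the ring atom that already bears the same group, therefore gives no readable difference in growth inhibition. Even an addition that brings in a whole six-membered aromatic ring and a chlorine leaves the read-out indistinguishable from that of the compound with a single such group, and no measurement at hand accounts for this flat result.

Among the compounds shown here, this single step covers only one group at one position, so it cannot show whether this carbon is insensitive to substitution in general or whether the result is particular to 2-(4-chlorophenyl)ethenyl. A small methyl group, a basic amine or a carboxylic acid at the same carbon could still shift the number in either direction, and the compounds shown give no hint of which would do so.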